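A few compounds are considered here, and "the series" means these few. Any claim that something is new, unique, unknown or untested is made for them only; others in the source may bear on it.

Compound 3 `Cc1nc(C(=O)Nc2cccc(NC(=O)COc3ccc4c(=O)ccoc4c3)c2)cs1` is measured in an assay on isolated protein for inhibition of Rho-associated protein kinase 2 (Homo sapiens), read by scintillation counting, radiometric assay and 33P incorporation, with a stated time of 40 min, in the presence of a further agent that is not named here (a lower number here means a stronger inhibitor, a higher number a weaker inhibitor), where it gives 33 nM. On the three numbers shown, compound 3 stands second highest: compound 1 `O=C(COc1ccc2c(=O)ccoc2c1)Nc1cccc(NC(=O)c2cccc([N+](=O)[O-])c2)c1` gives 41 nM in this assay, a number within the scatter of compound 3, and compound 2 `CC(C)(C)c1cc(C(=O)Nc2cccc(NC(=O)COc3ccc4c(=O)ccoc4c3)c2)no1` gives 5 nM, so that the step of a 6.6-fold higher number from compound 2 to compound 3 (0.82 log units; beyond the scatter) is the only one of the two that lies beyond the scatter; the step of a 1.2-fold lower number from compound 1 to compound 3 (0.09 log units; within the scatter) is small.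

Compound 4 `Nc1ccc(C(=O)Nc2cccc(NC(=O)COc3ccc4c(=O)ccoc4c3)c2)cc1` differs from compound 3 in one place: 4-aminophenyl in place of 2-methyl-1,3-thiazol-4-yl on a carbonyl carbon. Among the compounds with values here, the steps that bear on this change are a 1.2-fold lower number from compound 1 to compound 3 (0.09 log units; within the scatter), which exchanges a six-membered carbon ring for a five-membered ring with two hetero atoms at the same carbonyl carbon without moving the number beyond the scatter, and an 8.2-fold lower number from compound 1 to compound 2 (0.91 log units; beyond the scatter) together with a 6.6-fold higher number from compound 2 to compound 3 (0.82 log units; beyond the scatter), which show that the tert-butyl-substituted five-membered ring is the one group that sets itself apart. Since the substituted six-membered ring of compound 1 and the five-membered ring of compound 3 sit together, the return to a six-membered carbon ring in compound 4 is expected to bring no step beyond the scatter, the estimated step being a 1.2-fold higher number from compound 3 to compound 4 (0.08 log units; within the scatter). Compound 4 is therefore expected to give about 40 nM in this assay, within a range from 12 nM to 130 nM.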

Compound 4, half-maximal inhibitory concentration: 83 nM
Beside the measured number, compound 4's estimate is 2.1-fold (0.32 log units) below it; low and high end bracket the measured number.
By their numbers in this assay, from the lowest: compound 2; then compounds 3 and 1 (each within the scatter of the next); then compound 4.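

In this assay, within the data shown here, 4-aminophenyl is the first group on this carbonyl carbon to set a compound apart on the weak side, with compound 4 the weakest of the four (a 2.5-fold higher number from compound 3 to compound 4 (0.40 log units; beyond the scatter)) and (a 2.0-fold higher number from compound 1 to compound 4 (0.31 log units; beyond the scatter)), whereas compounds 1 and 3 sit within the scatter of each other. Compounds 1 and 4 both carry a six-membered aromatic ring of carbon only, so the ring type alone does not fix the number here, and what is attached to that ring also counts. Among these compounds, the span at this position also widens to a large step (a 17-fold higher number from compound 2 to compound 4 (1.22 log units; beyond the scatter)), and 5-(tert-butyl)-1,2-oxazol-3-yl remains the one group that gives a clearly stronger inhibitor.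

Nothing shown here gives a reason for these steps. From the compounds shown here alone, it remains open whether the gap between compounds 1 and 4 follows the kind of substituent or its place on the ring, which an unsubstituted phenyl or a 3-aminophenyl group would help to settle, and whether the tert-butyl group or the ring carrying it sets compound 2 apart, which a 5-methyl-1,2-oxazol-3-yl group would help to test.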